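The source may report more compounds than this note shows. Statements on the series, on what has been measured and on what is new or still open speak of the compounds shown alone.

Among the measured compounds shown here, in an ADME assay on microsomes from liver (Rattus norvegicus, strain Sprague-Dawley) for metabolic stability, read by LC-MS, using NADPH, with a stated time of 30 min, tested at 3 uM (on this read-out lower numbers stand for a less stable compound and higher numbers for a more stable compound), compound 3 `COc1ncc(-c2ccc(-c3cnc4c(c3)CN(C)C4=O)s2)cc1NS(=O)(=O)c1ccccc1[N+](=O)[O-]` gives 80%, the lowest of the three numbers measured so far. Compound 1 `O=C1NCc2ncc(-c3ccc(-c4cncc(NS(=O)(=O)c5ccc(F)cc5F)c4)s3)cc21` gives 100% and compound 2 `CN1Cc2cc(-c3ccc(-c4cncc(NS(=O)(=O)c5ccc(F)cc5F)c4)s3)cnc2C1=O` gives 100%, and each of these lies above compound 3 by more than the usual scatter.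

Compound 4 `COc1ncc(-c2ccc(-c3cnc4c(c3)CN(C)C4=O)s2)cc1NS(=O)(=O)c1ccc(F)cc1F` differs from compound 3 in one place: 2,4-difluorophenyl in place of 2-nitrophenyl on a sulfonyl sulfur. Put simply, 2,4-difluorophenyl stands in place of 2-nitrophenyl on a sulfonyl sulfur.

For the measured compounds named here, no measured step makes this exact swap. Going by the values given here, the only measured step, no change at the digits printed from compound 1 to compound 2 (within the scatter), concerns another part of the molecule and stays within the scatter, so it gives no direct size for this change. Compound 1 and compound 2 both carry 2,4-difluorophenyl, but they also differ from compound 3 elsewhere, which makes them only a partial guide. With compound 2 at 100% as that guide, a modest rise is expected, and the expected step is a number 10 percentage points higher from compound 3 to compound 4 (within the scatter). For compound 4 the estimated value is 90%, with an expected range of 75% to 100%.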

Compound 4, percent of the compound remaining in the Rattus norvegicus assay: 100%
Estimate against measurement, compound 4: 10 percentage points below; measured number inside the range.
By their numbers in the Rattus norvegicus assay, from the lowest: compound 3; then compounds 1, 2 and 4 (each within the scatter of the next).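

Among the compounds shown here, in the Rattus norvegicus assay, the earlier compounds could not isolate the group on the sulfonyl sulfur, and now the swap of 2-nitrophenyl for 2,4-difluorophenyl alone gives a number 20 percentage points higher from compound 3 to compound 4 (beyond the scatter). With 2,4-difluorophenyl in place, methoxy in place of hydrogen on an aromatic carbon gives no change at the digits printed from compound 2 to compound 4 (within the scatter), so this read-out shows no cost from the methoxy group in this pair. In a physicochemical assay for solubility, read by HPLC (a higher number here means a more soluble compound, a lower number a less soluble compound), compound 3 gives 4810 ug/mL and compound 4 gives 18300 ug/mL. The same swap on the sulfonyl sulfur also raises the number in the physicochemical assay: the measured solubility of compound 3, 4810 ug/mL, and of compound 4, 18300 ug/mL, a 3.8-fold higher number (0.58 log units; beyond the scatter)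

This single pair cannot separate the effect of losing 2-nitrophenyl from that of gaining 2,4-difluorophenyl. On these data alone, it remains open how an unsubstituted phenyl, or a phenyl carrying an amine or a carboxylic acid, would behave on the sulfonyl sulfur in either read-out.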